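The source may hold more compounds than are shown below. What is called first, only, known or untested is meant among the compounds shown, and "the series" means these compounds.

Compound 2 `CCOC(=O)c1cnc(-c2ccccc2[N+](=O)[O-])[nH]c1=O` stands without a number in a functional assay on the whole organism (strain Sprague-Dawley) for inhibition, with Rattus norvegicus as the target, with a stated time of 10 min (a lower number here means that less compound is needed, a higher number that more compound is needed for the effect), its entry being "not determined" (no result reported). Compound 1 `CSc1ccccc1-c1ncc(C(=O)O)c(=O)[nH]1` gives only a limit in this assay, > 20 mg/kg, and that is the limit of > 20 mg/kg in this assay, at which 1 of the 2 values shown sits. Compound 3 `CCOC(=O)c1cnc(-c2ccccc2SCC)[nH]c1=O` differs from compound 2 by ethylsulfanyl in place of nitro on an aromatic carbon. Among the measured compounds shown here, with no measured step between compounds to lean on, no shift beyond the usual scatter in this assay is expected in either direction from this change. Compound 3 is therefore estimated to need about 25 mg/kg in this assay, within a range from 8 mg/kg to 80 mg/kg.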

Compound 3, dose for 50% inhibition: > 5 mg/kg
Compound 3: only a limit was reported; the forecaster's own chance of this, stated with the estimate: 60%; the middle value does not contradict the limit.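

No step can be read from compound 2 to compound 3 in this assay. Compound 3 gives only a limit there, > 5 mg/kg. The compounds shown leave open whether ethylsulfanyl in place of nitro shifts the read-out of this assay, and by how much.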